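Turning a methyl back into a tolyl on the sulfur-bound carbon

The compounds below may be only part of what the source reports. "The series", "measured", "known", "first", "only" and "open" are said of these compounds alone.

Of the compounds shown here, two sharing one core have been tested in a functional assay on HeLa cells (Homo sapiens) for antiproliferative activity, read by CCK-8 assay, with a stated time of 48 h; a higher number here means a weaker inhibitor, a lower number a stronger inhibitor. Compound 1, `O=c1c2ccccc2[se]n1-c1nc(SCc2ccccc2)n[nH]1`, carries a benzyl group on its sulfur; in this assay compound 1 reaches only the limit of > 50000 nM, which is a boundary of the assay and not a number. Compound 2, `CCSc1n[nH]c(-n2[se]c3ccccc3c2=O)n1`, carries an ethyl group instead; in this assay compound 2 gives 14100 nM. Among the compounds with values here, this is the only real number among the two results, the other being a limit. Within the data shown here, the one measured step, an at least 3.5-fold lower number from compound 1 to compound 2 (0.54 log units; beyond the scatter), can be stated only as an at-least figure because of the limit of > 50000 nM in this assay, at which 1 of the 2 values shown sits.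

Compound 3, `Cc1ccc(CSc2n[nH]c(-n3[se]c4ccccc4c3=O)n2)cc1`, reverses much of that step: 4-methylphenyl in place of methyl on a saturated chain carbon bound to a sulfur. Since moving from the benzyl of compound 1 to the ethyl of compound 2 lowered the number by at least the amount in an at least 3.5-fold lower number from compound 1 to compound 2 (0.54 log units; beyond the scatter), restoring an aromatic ring is expected to raise it again, with a fair chance that only a limit is reported. The expected step is a 3.2-fold higher number from compound 2 to compound 3 (0.50 log units; beyond the scatter). Compound 3 is therefore estimated at 45000 nM, with a range from 15000 nM to 150000 nM.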

Compound 3, half-maximal inhibitory concentration: 34800 nM
Estimate against measurement, compound 3: 1.3-fold (0.11 log units) above; low and high end bracket the measured number.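

Compound 3 gives a real number for an aromatic ring on a saturated chain carbon bound to a sulfur, so the drop in activity on going from ethyl to a benzyl-type group, earlier known only as an at-least figure, now has a measured size in this assay: a 2.5-fold higher number from compound 2 to compound 3 (0.39 log units; beyond the scatter). Compound 1 stands at > 50000 nM, which is a limit of the assay and not a number. Set against that limit, the methyl in place of hydrogen on an aromatic carbon can be read only as an at least 1.4-fold lower number from compound 1 to compound 3 (0.15 log units; that floor lies within the scatter), a floor too small to place compound 3 and compound 1 in any order, and the true size of this step remains unknown: the limit of > 50000 nM in this assay, at which 1 of the 3 values shown sits.

The compounds shown leave open whether activity changes steadily with the size of the group on sulfur, which a propyl or butyl chain would help to settle. They also leave open whether a group of a different kind at the end of that chain, such as an amine or a carboxylic acid, would do better than the ethyl of compound 2.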